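Swapping Chloro for Nitro at the Cytotoxicity Ceiling

This account rests on a few compounds, and the source may have more. Where it says the series, first, only, none or still open, it means among the compounds named here.

Three compounds sharing one core were tested in an ADME assay on HEL cells (Homo sapiens) for cytotoxicity; a higher number here means that more compound is tolerated, a lower number that less compound is tolerated. Compound 1 `O=C(c1ccc([N+](=O)[O-])cc1)n1ccnc1-c1ccccc1[N+](=O)[O-]` carries two nitro groups. In this assay compound 1 reaches only the limit of > 100 ug/mL, which is a boundary of the test and not a measured number. Compound 2 `O=C(c1ccc([N+](=O)[O-])cc1)n1ccnc1-c1ccccc1Cl` has chloro in place of nitro on an aromatic carbon. In this assay compound 2 likewise gives only the limit of > 100 ug/mL. Compound 3 `O=C(c1ccc([N+](=O)[O-])cc1)n1ccnc1-c1ccc(Cl)cc1` has 4-chlorophenyl in place of 2-chlorophenyl on an aromatic carbon. In this assay compound 3 again stops at the limit of > 100 ug/mL. Compound 3 therefore stands exactly where every measured compound stands, at the ceiling of the assay: the limit of > 100 ug/mL in this assay, at which 3 of the 3 values shown sit. The step that the two limits leave unreadable from compound 1 to compound 2 is unreadable, and so is a step that the two limits leave unreadable from compound 2 to compound 3, each running between two limits.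

Compound 4 `O=C(c1ccc([N+](=O)[O-])cc1)n1ccnc1-c1ccc([N+](=O)[O-])cc1` differs from compound 3 by nitro in place of chloro on an aromatic carbon. No measured step gives a readable size for such a change, but every compound shown, with or without a second nitro, sits at the same ceiling. The step of a number no higher from compound 3 to compound 4 (the limit leaves the size open) is expected to be none beyond the scatter. Compound 4 is estimated at 100 ug/mL, between 40 ug/mL and 250 ug/mL, most likely again reported only as a limit.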

Compound 4, minimum cytotoxic concentration: > 100 ug/mL
Compound 4 ended at the assay's limit; the forecaster's own chance of this, stated with the estimate: 85%; the middle value sits exactly at the limit.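

No size can be read for the change from compound 3 to compound 4, with both compounds reported only as a limit of the test and not as a measured number: the limit of > 100 ug/mL in this assay, at which 4 of the 4 values shown sit.

On these data alone, whether compound 1, compound 2, compound 3 and compound 4 differ at all in this assay stays open, as does which change to the shared core, if any, would give a readable number.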